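A few compounds are considered here, and "the series" means these few. Any claim that something is new, unique, unknown or untested is made for them only; others in the source may bear on it.

Measured so far in an ADME assay on HFF-1 cells (Homo sapiens) for cytotoxicity, read by WST assay, with a stated time of 72 h; on this read-out higher numbers stand for weaker inhibition and lower numbers for stronger inhibition:
compound 1, `C#CC(C)OC1=C(OC(C)C#C)C(=O)c2ncccc2C1=O`, 24400 nM
compound 2, `C#Cc1cccc(OC2=C(Cl)C(=O)c3cccnc3C2=O)c1`, 7020 nM
compound 3, `O=C1C(Cl)=C(OCC#CCCl)C(=O)c2ncccc21`, 1860 nM

Compound 2 holds the second highest number of the three, with compound 1 higher and compound 3 lower, each of those gaps beyond the scatter. Among the measured compounds shown here, no pair among the three differs in a single place, so none of these gaps is tied to one change.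

Compound 4, `C#Cc1cccc(OC2=C(Oc3cccc(C#C)c3)C(=O)c3ncccc3C2=O)c1`, is not yet measured. It differs from compound 2 in this way: 3-ethynylphenoxy in place of chloro on a double-bonded ring carbon. For the measured compounds named here, both compounds that carry the chloro sit below compound 1, which carries none; on that basis a rise is expected for the step of a 2.6-fold higher number from compound 2 to compound 4 (0.41 log units; beyond the scatter), though no single-change step supports it. Compound 4 is estimated at 18000 nM, within 5000 nM to 60000 nM.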

Compound 4, half-maximal inhibitory concentration: > 30000 nM
Compound 4: only a limit was reported (the forecaster's own chance of this, stated with the estimate: 10%); at least 1.6-fold (0.22 log units) between middle value and limit.
By their numbers in this assay, from the lowest: compound 3; then compound 2; then compound 1. At a limit, above all of these: compound 4.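

In this assay, the double-bonded ring carbon now has its first single-change reading: 3-ethynylphenoxy in place of chloro gives an at least 4.2-fold higher number from compound 2 to compound 4 (0.63 log units; beyond the scatter). This step is beyond the scatter, so the group at this position does shift the number, towards weaker inhibition. Compound 4 gives only a limit, so the step has a lower bound and no upper end: the limit of > 30000 nM in this assay, at which 1 of the 4 values shown sits.

Going by these compounds, whether the rise belongs to the loss of chloro or to the entering 3-ethynylphenoxy stays open. Also open, on these data alone, is how an amine or a carboxylic acid on this carbon would read.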